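Pyrrolidine Ring Replaced by Open Diamine Chain

The compounds below may be only part of what the source reports. "The series", "measured", "known", "first", "only" and "open" are said of these compounds alone.

Compound 1 `CCCCCCCCCCc1ccc(-c2noc(CCCCN)n2)cc1` gives 55% in an assay on HeLa cells for inhibition of sphingosine-1-phosphate transporter SPNS2 (Mus musculus), read by LC-MS, tested at 2 uM; a higher number here means more inhibition at the concentration tested (going by the name of the read-out), a lower number less inhibition.
Compound 2 `CCCCCCCCCCc1ccc(-c2noc(CC3CCNC3)n2)cc1` gives 44%.

Compound 2 stands lowest of the two numbers measured; its nearest neighbour is compound 1, and the step of a number 11 percentage points lower from compound 1 to compound 2 (beyond the scatter) is the only one known. Compound 3 `CCCCCCCCCCc1ccc(-c2noc([C@@H](N)CCN)n2)cc1` differs from compound 2 by 1,3-diaminopropyl in place of (pyrrolidin-3-yl)methyl on an aromatic carbon. This change reverses the direction of that one known step: the ring of compound 2 is opened again into a chain that, like the 3-aminopropyl of compound 1, ends in a free amine, while a second amine is added. For the measured compounds named here, only the step from compound 1 to compound 2 bears on the question, and it was modest. Compound 3 is therefore expected to recover roughly that amount, a step of a number 11 percentage points higher from compound 2 to compound 3 (beyond the scatter) upward, and its inhibition is estimated at 55% with a range from 35% to 75%.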

Compound 3, a percentage reported as inhibition, at one concentration (the size of the read-out at that concentration, not a potency): 14%
Compound 3: middle estimate off by 41 percentage points, on the high side; the measured number lies below the stated range.
By their numbers in this assay, from the lowest: compound 3; then compound 2; then compound 1.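

The open chain did not behave as the reverse of the earlier ring closure: a number 30 percentage points lower from compound 2 to compound 3 (beyond the scatter), and a number 41 percentage points lower from compound 1 to compound 3 (beyond the scatter), leaving compound 3 lowest of the three in this assay. At this aromatic carbon, then, having an open chain rather than a ring does not by itself keep inhibition, and two open chains, 4-aminobutyl and 1,3-diaminopropyl, lie far apart. No measurement is available that would explain this drop.

The compounds shown leave open whether the loss goes with the second amine or with the defined stereocentre, as 1,3-diaminopropyl brings both at once. Also open, as far as these compounds go, is how the mirror-image form of compound 3, a piperidine ring or a longer chain ending in a single amine would read at this position.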